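A few compounds are considered here, and "the series" means these few. Any claim that something is new, unique, unknown or untested is made for them only; others in the source may bear on it.

Compound 1 `Nc1nc(OCC(F)(F)F)c2ncn(/C=C3/CC3(CO)CO)c2n1`, compound 2 `CCCCCCSc1nc(N)nc2c1ncn2/C=C1/CC1(CO)CO` and compound 3 `Nc1nc2c(ncn2/C=C2/CC2(CO)CO)c(=O)[nH]1` share one core and were all run in an ADME assay on MOLT-3 cells (Homo sapiens) for cytotoxicity, with a stated time of 7 days; on this read-out higher numbers stand for lower toxicity in this test and lower numbers for higher toxicity in this test. In this assay compound 1 reaches only the limit of > 20000 nM. In this assay compound 2 likewise gives only the limit of > 20000 nM. In this assay compound 3 also stops at the limit of > 20000 nM. Compound 2 thus stands at the limit of the test, indistinguishable on the numbers from the other two, and the limit of > 20000 nM in this assay, at which 3 of the 3 values shown sit, sums up the whole measured set. Among the measured compounds shown here, the one measured step touching compound 2, a step that the two limits leave unreadable from compound 1 to compound 2, runs between two limits and its size cannot be read.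

Compound 4 `C=CCOc1nc(N)nc2c1ncn2/C=C1/CC1(CO)CO` is not yet measured. It differs from compound 2 as follows: allyloxy in place of hexylsulfanyl on an aromatic carbon

For the measured compounds named here, the only measured step bearing on this change is a step that the two limits leave unreadable from compound 1 to compound 2, which exchanged one group on an aromatic carbon and left both limits in place; no readable size is available, and no step beyond the scatter has been seen anywhere in the set. No change beyond the scatter is therefore expected, and the step of a number no higher from compound 2 to compound 4 (the limit leaves the size open) is estimated as flat. Compound 4 is expected at 20000 nM, within 8000 nM to 80000 nM, most likely again reported only as a limit.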

Compound 4, half-maximal cytotoxic concentration: > 20000 nM
Compound 4: only a limit was reported; the forecaster's own chance of this, stated with the estimate: 85%; the middle value lies on the limit itself.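

In this assay compound 4 gives > 20000 nM as a limit. Among the compounds shown here, the steps from compound 1 and compound 2 to compound 4 run between limits and cannot be read, so compound 4 adds no new step. The compounds shown leave open whether any group on this aromatic carbon changes cytotoxicity, and where the true values of all four compounds lie.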